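Trichlorophenyl Chalcone: Expected Cytotoxicity from Aryl Swaps

A few compounds are considered here, and "the series" means these few. Any claim that something is new, unique, unknown or untested is made for them only; others in the source may bear on it.

Three chalcones carrying the same benzyloxy-bearing half have been tested in a functional assay on PANC-1 cells (Homo sapiens) for cytotoxicity, read by MTT assay, with a stated time of 68 h; a lower number here means a stronger inhibitor, a higher number a weaker inhibitor. Compound 1 `COc1ccc(C(=O)/C=C/c2cccc(OCc3ccccc3)c2)cc1` gives 44300 nM, the largest of the three numbers, though its steps to both neighbours lie within the scatter. Compound 2 `O=C(/C=C/c1cccc(OCc2ccccc2)c1)c1ccc([N+](=O)[O-])cc1` gives 25400 nM, and compound 3 `O=C(/C=C/c1cccc(OCc2ccccc2)c1)c1ccccc1` gives 23500 nM. Replacing the methoxy with nitro gives a 1.7-fold lower number from compound 1 to compound 2 (0.24 log units; within the scatter); replacing it with hydrogen gives a 1.9-fold lower number from compound 1 to compound 3 (0.28 log units; within the scatter); and between those two, a 1.1-fold lower number from compound 2 to compound 3 (0.03 log units; within the scatter).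

Compound 4 `O=C(/C=C/c1cccc(OCc2ccccc2)c1)c1ccc(Cl)c(Cl)c1Cl` differs from compound 1 as follows: 2,3,4-trichlorophenyl in place of 4-methoxyphenyl on a carbonyl carbon. The two measured steps that bear on this, from compound 1 to compound 2 and from compound 1 to compound 3, both alter the same ring on the carbonyl carbon and both stay within the scatter. The change to compound 4 is larger in what it swaps, yet nothing measured here suggests a step beyond the scatter. The expected step is therefore a 1.7-fold lower number from compound 1 to compound 4 (0.23 log units; within the scatter), with compound 4 estimated at 26000 nM in this assay, within a range of 9000 nM to 75000 nM.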

Compound 4, half-maximal inhibitory concentration: 2400 nM
Compound 4: the middle estimate sits 11-fold (1.03 log units) above what was measured, and the stated range ends above it.
By their numbers in this assay, from the lowest: compound 4; then compounds 3, 2 and 1 (each within the scatter of the next).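

In this assay the ring on the carbonyl carbon proves able to shift the number well beyond the scatter: compounds 1, 2 and 3 stay within the scatter of one another, yet an 18-fold lower number from compound 1 to compound 4 (1.27 log units; beyond the scatter) comes with 2,3,4-trichlorophenyl on that carbon. The other two rings give the same picture, with a 9.8-fold lower number from compound 3 to compound 4 (0.99 log units; beyond the scatter) and an 11-fold lower number from compound 2 to compound 4 (1.02 log units; beyond the scatter) in the same direction, so the drop does not hang on one particular starting ring. Nothing available here explains why this ring stands apart.

The compounds shown leave open whether all three chlorines are needed, which phenyl rings carrying one or two chlorines would help to settle. As far as these compounds go, it also remains open how other groups on this ring, such as a methyl, an amine or a carboxylic acid, would compare.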